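This account rests on a few compounds, and the source may have more. Where it says the series, first, only, none or still open, it means among the compounds named here.

In a functional assay on HCT-116 cells (Homo sapiens) for cytotoxicity, read by MTT assay (on this read-out lower numbers stand for stronger inhibition and higher numbers for weaker inhibition), compound 1 `Cc1cc(O)c(C(=O)/C=C/c2ccc(Cl)cc2)c(=O)o1` gives 87400 nM and compound 2 `Cc1cc(O)c(C(=O)/C=C/c2ccc(Cl)cc2Cl)c(=O)o1` gives 88700 nM. Compound 1 therefore stands level with compound 2, with a 1.0-fold higher number from compound 1 to compound 2 (0.01 log units; within the scatter). Compound 3 `Cc1cc(O)c(C(=O)/C=C/c2ccc(Cl)c(Cl)c2)c(=O)o1` returns only a limit, > 100000 nM. That leaves an at least 1.1-fold higher number from compound 1 to compound 3 (0.05 log units; that floor lies within the scatter). Compound 4 `Cc1cc(O)c(C(=O)/C=C/c2ccc(-c3ccccc3)cc2)c(=O)o1` carries a different change, (phenyl in place of chloro on an aromatic carbon), with phenyl in place of chloro on an aromatic carbon, para to a large group. The two measured steps bear on it only indirectly, since each adds chloro in place of hydrogen on an aromatic carbon. Neither shows a change beyond the scatter, so no step beyond the scatter is expected in this assay. The expected change is a 1.5-fold lower number from compound 1 to compound 4 (0.16 log units; within the scatter). For compound 4 the estimated value is 60000 nM, within an expected range of 20000 nM to 100000 nM.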

Compound 4, half-maximal inhibitory concentration: > 100000 nM
Compound 4 gave a limit, no number (the forecaster's own chance of this, stated with the estimate: 30%); middle value at least 1.6-fold (0.22 log units) away from the limit.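

In this assay, for the compounds shown here, replacing the chloro itself with phenyl, rather than adding a second chloro as the earlier steps did, leaves an at least 1.1-fold higher number from compound 1 to compound 4 (0.05 log units; that floor lies within the scatter). The larger ring at this position therefore brings no stronger inhibition, and the expected move to a lower number does not appear. Compound 4 gives a limit, not a number, so the true size of the step cannot be read: the limit of > 100000 nM in this assay, at which 2 of the 4 values shown sit.

The compounds shown leave open whether an amine, a carboxylic acid or a methoxy group at this position would give a lower number than compound 1. They also leave open whether any change here moves the number beyond the scatter.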